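Hexylamino in place of dipentylamino on a shared core

A few compounds are considered here, and "the series" means these few. Any claim that something is new, unique, unknown or untested is made for them only; others in the source may bear on it.

In a functional assay on B16-F10 cells (Mus musculus) for inhibition, read by MTT assay, with a stated time of 48 h (a higher number here means a weaker inhibitor, a lower number a stronger inhibitor), three compounds sharing one core have been measured. Compound 1 `C#CCNC(=O)/C=C/c1c(/C=C/c2ccc(OC)cc2)cc(OC)cc1OC` gives 8280 nM. Compound 2 `COc1ccc(/C=C/c2cc(OC)cc(OC)c2/C=C/C(=O)Nc2cc(OC)c(OC)c(OC)c2)cc1` gives 8150 nM. Compound 3 `CCCCCN(CCCCC)C(=O)/C=C/c1c(/C=C/c2ccc(OC)cc2)cc(OC)cc1OC` gives 9270 nM, level with the other two, as its gaps to both lie within the scatter of repeated measurements.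

Compound 4 `CCCCCCNC(=O)/C=C/c1c(/C=C/c2ccc(OC)cc2)cc(OC)cc1OC` has not yet been measured. It carries hexylamino in place of dipentylamino on a carbonyl carbon. Two measured steps changed the same part of the molecule. Dipentylamino in place of propargylamino on a carbonyl carbon gave a 1.1-fold higher number from compound 1 to compound 3 (0.05 log units; within the scatter), and 3,4,5-trimethoxyphenyl in place of propargyl on an amide-type nitrogen gave a 1.0-fold lower number from compound 1 to compound 2 (0.01 log units; within the scatter). Neither step goes beyond the scatter. Three compounds are a thin guide, but no step beyond the scatter is expected in this assay for this change. The estimated step is a 1.1-fold lower number from compound 3 to compound 4 (0.04 log units; within the scatter). Compound 4 is expected at about 8500 nM, with an estimated range of 5000 nM to 14000 nM.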

Compound 4, half-maximal inhibitory concentration: 7180 nM
The estimate for compound 4 lay 1.2-fold (0.07 log units) above the measured number; measured number inside the range.
By their numbers in this assay, from the lowest: compounds 4, 2, 1 and 3 (each within the scatter of the next).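

In this assay, hexylamino in place of dipentylamino on the carbonyl carbon gives a 1.3-fold lower number from compound 3 to compound 4 (0.11 log units; within the scatter), so this change stays within the scatter even though hexylamino brings a hydrogen-bond donor that dipentylamino lacks. The other two comparisons agree: hexyl in place of 3,4,5-trimethoxyphenyl on the amide-type nitrogen gives a 1.1-fold lower number from compound 2 to compound 4 (0.06 log units; within the scatter), and pentyl in place of ethynyl on the saturated chain carbon gives a 1.2-fold lower number from compound 1 to compound 4 (0.06 log units; within the scatter). No measurement is available that would account for these small steps.

As far as these compounds go, what remains open is whether any group at this position can move the number beyond the scatter. A chain ending in an amine or a carboxylic acid, or a longer chain such as dodecyl, would test that.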